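The compounds below may be only part of what the source reports. "The series", "measured", "known", "first", "only" and "open" are said of these compounds alone.

Measured in a functional assay (Homo sapiens) for inhibition; a higher number here means a weaker inhibitor, a lower number a stronger inhibitor:
Compound 1 `CS(=O)(=O)c1ccc(CSc2nc(-c3ccc(F)cc3)c(-c3ccncc3)[nH]2)cc1`: 330 nM
Compound 2 `C[S+]([O-])c1ccc(O)c(CSc2nc(-c3ccc(F)cc3)c(-c3ccncc3)[nH]2)c1`: 1000 nM

Of these two, compound 2 carries the higher number, at 1000 nM, which makes it the weaker inhibitor. Compound 3 `CSc1cc(Cl)cc(CSc2nc(-c3ccc(F)cc3)c(-c3ccncc3)[nH]2)c1O` is not yet measured. It keeps the core of compound 2 and differs from it as follows: a group of 10 heavy atoms (7 carbon, 1 oxygen, 1 sulfur, 1 chlorine; one six-membered aromatic ring of carbon only) in place of a group of 10 heavy atoms (7 carbon, 2 oxygen, 1 sulfur; one six-membered aromatic ring of carbon only), on a saturated chain carbon bound to a sulfur. The new group is 5-chloro-2-hydroxy-3-(methylsulfanyl)phenyl. Among the compounds with values here, only one measured step bears on this change, the swap at the same place, a 3.0-fold higher number from compound 1 to compound 2 (0.48 log units; beyond the scatter). Within the data shown here, that step is modest, and no measured compound carries a chlorine, so the direction is poorly defined. A step of similar or smaller size in this assay is therefore expected, leaning slightly towards a lower number. The expected change is a 1.4-fold lower number from compound 2 to compound 3 (0.15 log units; within the scatter). Compound 3 is estimated at 700 nM, with an expected range of 200 nM to 2500 nM.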

Compound 3, half-maximal inhibitory concentration: 640 nM
Estimate against measurement, compound 3: 1.1-fold (0.04 log units) above, and the stated range covers the measured number.
By their numbers in this assay, from the lowest: compounds 1, 3 and 2 (each within the scatter of the next, the first and the last beyond it).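

In this assay, putting 5-chloro-2-hydroxy-3-(methylsulfanyl)phenyl on the saturated chain carbon bound to a sulfur gives a 1.6-fold lower number from compound 2 to compound 3 (0.19 log units; within the scatter), and set against 4-(methylsulfonyl)phenyl the same group gives a 1.9-fold higher number from compound 1 to compound 3 (0.29 log units; within the scatter). Compound 3 therefore cannot be told apart from either compound 1 or compound 2, even though those two are separated by a 3.0-fold higher number from compound 1 to compound 2 (0.48 log units; beyond the scatter), so a group carrying a chlorine and a methylsulfanyl is accommodated here without a step beyond the scatter from either. Nothing measured here offers an explanation for this result.

From the compounds shown here alone, the chlorine and the methylsulfanyl enter together, so what each contributes alone remains open. Also open, going by these compounds, is how this position would respond to an amine or a carboxylic acid on the ring, or to a longer chain in place of the methylsulfanyl.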